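The compounds below may be only part of what the source reports. "The series", "measured", "known", "first", "only" and "open" are said of these compounds alone.

Of the compounds shown here, three have been measured in an ADME assay on liver for metabolic stability, with Liver microsome (Homo sapiens) as the target, read by LC-MS, using microsomes (a lower number here means slower removal, a higher number faster removal of the compound), and a fourth awaits measurement. Compound 1, with the structure `CC(C)(C)[C@@H](O)C(=O)N1[C@@H]2C[C@@H]2C[C@H]1C(=O)NCc1cc(Cl)ccc1-n1cnnn1`, is the only one of the three for which a definite number exists: in this assay compound 1 gives 54 mL.min-1.g-1. Compound 2, with the structure `O=C(NCc1cc(Cl)ccc1-n1cnnn1)[C@@H]1[C@H]2C[C@H]2CN1C(=O)[C@H](O)CC1CC1`, gives only a limit in this assay, namely < 14 mL.min-1.g-1, which is the limit of < 14 mL.min-1.g-1 in this assay, at which 1 of the 3 values shown sits. Compound 3, with the structure `O=C(NCc1cc(Cl)ccc1-n1cnnn1)[C@@H]1CCON1C(=O)[C@H](O)c1ccccc1`, likewise gives only a limit in this assay, namely < 12 mL.min-1.g-1, which is the limit of < 12 mL.min-1.g-1 in this assay, at which 1 of the 3 values shown sits. Among the compounds with values here, compound 1 therefore stands apart as the one compound whose removal was fast enough for this assay to report a number rather than a limit.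

Compound 4, with the structure `CCCC[C@@H](O)C(=O)N1[C@@H]2C[C@@H]2C[C@H]1C(=O)NCc1cc(Cl)ccc1-n1cnnn1`, has not yet been measured. It differs from compound 1 in a single place: butyl in place of tert-butyl on a saturated chain carbon bound to a carbonyl carbon and an oxygen on a saturated carbon. Within the data shown here, no pair of the measured compounds differs in only one place, so no measured step of this kind exists to lean on. The expected change, a 1.5-fold higher number from compound 1 to compound 4 (0.17 log units; within the scatter), is a small one towards faster removal, of a size that may well sit within the usual scatter. In this assay compound 4 is estimated at 80 mL.min-1.g-1, with a range from 40 mL.min-1.g-1 to 160 mL.min-1.g-1.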

Compound 4, intrinsic clearance in microsomes: 89 mL.min-1.g-1
For compound 4 the middle estimate is 1.1-fold (0.05 log units) below the measured one; measured number inside the range.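

Within the data shown here, this is the first step in the set that can be read at a single place. In this assay, putting butyl in place of tert-butyl, on a saturated chain carbon bound to a carbonyl carbon and an oxygen on a saturated carbon, gives a 1.6-fold higher number from compound 1 to compound 4 (0.22 log units; within the scatter). On the core of compound 1, these two groups, made of the same atoms joined differently, therefore cannot be told apart in this assay. Nothing measured here offers a reason for this result.

On these data alone, it remains open whether a longer chain such as hexyl, or a chain carrying an amine or a carboxylic acid, would give a step beyond the scatter at this place. Compound 2 and compound 3 differ from compound 1 in more than one place and give only limits, so they cannot show how the groups they carry at this place would behave on the core of compound 1.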